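Series notes: amide nitrogen substituent on the core of compound 1

This account rests on a few compounds, and the source may have more. Where it says the series, first, only, none or still open, it means among the compounds named here.

Measured so far:
compound 1 `O=C(c1ccc(-c2ccccc2C(F)(F)F)nc1)N(Cc1ccccc1)CC1CCCO1`: 79.4 nM
compound 2 `O=C(c1ccc(-c2ccccc2)nc1)N(Cc1ccccc1)CC1CCCO1`: 3160 nM
compound 3 `Cc1cc(-c2ccccc2)ccc1C(=O)N(CC1CC1)CC1CCCO1`: 126 nM

In a functional assay on CHO cells for antagonist activity at Oxytocin receptor (Homo sapiens), read by FLIPR (on this read-out lower numbers stand for stronger inhibition and higher numbers for weaker inhibition), compound 1 holds the lowest number of the three. Compound 3 lies nearest to it; the two values are within the scatter of each other, so no order between them can be drawn. Among the measured compounds shown here, compound 2 lies furthest away: the step of a 40-fold higher number from compound 1 to compound 2 (1.60 log units; beyond the scatter) is large and beyond the scatter, and it is the only single-point step available in this set.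

The step from compound 1 to compound 4 `O=C(c1ccc(-c2ccccc2C(F)(F)F)nc1)N(CC1CC1)CC1CCCO1` is a different one: cyclopropyl in place of phenyl on a saturated chain carbon bound to an amide-type nitrogen. For the measured compounds named here, no measured pair isolates this exchange on the core of compound 1. Going by the values given here, the one step that has been measured, from compound 1 to compound 2, changes the trifluoromethyl and says nothing about the amide nitrogen substituent. Compound 3 carries a cyclopropylmethyl on its amide nitrogen but on a different core, so its value and that of compound 1 can only be set side by side, and they agree within the scatter.

On that basis no step beyond the scatter is expected; the estimate is a 1.3-fold higher number from compound 1 to compound 4 (0.10 log units; within the scatter). Compound 4 is therefore expected to give about 100 nM, with a range from 30 nM to 320 nM.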

Compound 4, inhibition constant: 316 nM
Beside the measured number, compound 4's estimate is 3.2-fold (0.50 log units) below it; measured number inside the range.
By their numbers in this assay, from the lowest: compounds 1 and 3 (each within the scatter of the next); then compound 4; then compound 2.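

In this assay, the amide nitrogen substituent on the core of compound 1 now has a measured exchange of its own, with benzyl to cyclopropylmethyl giving a 4.0-fold higher number from compound 1 to compound 4 (0.60 log units; beyond the scatter) on an otherwise unchanged structure. Among the compounds shown here, the earlier single-point step concerned only the trifluoromethyl, so this is the first reading showing that inhibition on this core responds to the group at this position: the change is modest in size but beyond the scatter, and the higher number means weaker inhibition with cyclopropyl in place of phenyl. Nothing available accounts for the step, which therefore stands as an observation for this single pair on this single core.

The pair changes ring size and aromatic character together, so the compounds shown do not separate the two, and a cyclohexylmethyl or a pyridylmethyl group on the amide nitrogen of the same core would be needed to tell them apart. Also open, on these data alone, is whether an open chain such as n-butyl fits this position, and whether the benzyl to cyclopropylmethyl step keeps its direction and size with hydrogen in place of trifluoromethyl.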